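The source may hold more compounds than are shown below. What is called first, only, known or untested is meant among the compounds shown, and "the series" means these compounds.

Compound 1 `CC1=C(/C=C/C(=O)/C=C/c2cccc(F)c2)C(C)(C)CCC1O`: 4400 nM
Compound 2 `CC1=C(/C=C/C(=O)/C=C/c2cc(F)cc(C(F)(F)F)c2)C(C)(C)CCC1O`: 1100 nM

In a functional assay on LNCaP cells (Homo sapiens) for cytotoxicity, read by MTT assay, with a stated time of 72 h (a higher number here means a weaker inhibitor, a lower number a stronger inhibitor), compound 1 gives the highest of the two numbers; the nearest is compound 2, reached by a 4.0-fold lower number from compound 1 to compound 2 (0.60 log units; beyond the scatter). Compound 3 `CC1=C(/C=C/C(=O)/C=C/c2cccc(C#N)c2)C(C)(C)CCC1O` differs from compound 1 by cyano in place of fluoro on an aromatic carbon, on the same ring that carries the trifluoromethyl in compound 2. Among the compounds with values here, no measured step exchanges one small group for another on this ring; the only step that bears on it, from compound 1 to compound 2, adds a group rather than swapping one. A smaller shift is therefore expected, downward if at all and close to the scatter: a 1.5-fold lower number from compound 1 to compound 3 (0.17 log units; within the scatter). Compound 3 is estimated at 3000 nM, between 1200 nM and 8000 nM.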

Compound 3, half-maximal inhibitory concentration: 1800 nM
For compound 3 the middle estimate is 1.7-fold (0.22 log units) above the measured one, within the range that was stated.
By their numbers in this assay, from the lowest: compounds 2 and 3 (each within the scatter of the next); then compound 1.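

In this assay, changing 3-fluorophenyl to 3-cyanophenyl gives a 2.4-fold lower number from compound 1 to compound 3 (0.39 log units; beyond the scatter). A one-for-one exchange on this aromatic carbon therefore moves the number beyond the scatter, whereas the earlier step, a 4.0-fold lower number from compound 1 to compound 2 (0.60 log units; beyond the scatter), kept the fluoro and added a trifluoromethyl. No measurement is available that would account for this step. Going by these compounds, whether an amine or a carboxylic acid on this carbon would lower the number further remains open. So does whether the cyano exchange would have the same effect with a trifluoromethyl also on the ring.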